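Bromo in Place of Methoxy: What Compound 4 Might Show

The compounds below may be only part of what the source reports. "The series", "measured", "known", "first", "only" and "open" are said of these compounds alone.

Compound 1, `O=C(NCc1ccccc1)c1csc(-c2c[nH]c3ccccc23)n1`, in a functional assay on LNCaP cells (Homo sapiens) for cytotoxicity, read by MTT assay, with a stated time of 48 h, in the presence of a further agent that is not named here (a higher number here means a weaker inhibitor, a lower number a stronger inhibitor), gives > 100000 nM, which is a limit of the assay.
Compound 2, `COc1ccc2[nH]cc(-c3nc(C(=O)Nc4cc(OC)c(OC)c(OC)c4)cs3)c2c1`, in this assay gives 84800 nM.
Compound 3, `O=C(Nc1ccccc1)c1csc(-c2c[nH]c3ccccc23)n1`, in this assay gives > 100000 nM, which is a limit of the assay.

Among the measured compounds shown here, compound 2 thus stands as the only real number here; the other two values sit at the limit of > 100000 nM in this assay, at which 2 of the 3 values shown sit. For the measured compounds named here, the single measured step, a step that the two limits leave unreadable from compound 1 to compound 3, runs between two limits and cannot be read.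

Compound 4, `COc1cc(NC(=O)c2csc(-c3c[nH]c4ccc(Br)cc34)n2)cc(OC)c1OC`, differs from compound 2 by bromo in place of methoxy on an aromatic carbon. Going by the values given here, no measured step involves a change of this kind, so nothing in the data points to a shift in either direction beyond the scatter. Compound 4 is therefore expected to give about 70000 nM in this assay, within a range from 15000 nM to 250000 nM. The expected step of a 1.2-fold lower number from compound 2 to compound 4 (0.08 log units; within the scatter) is estimated to stay within the scatter, and a limit rather than a number remains quite possible.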

Compound 4, half-maximal inhibitory concentration: > 100000 nM
Compound 4: a limit, no number; the forecaster's own chance of this, stated with the estimate: 40%; middle value at least 1.4-fold (0.15 log units) away from the limit.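

Bromo in place of methoxy on this aromatic carbon gives an at least 1.1-fold higher number from compound 2 to compound 4 (0.07 log units; that floor lies within the scatter) in this assay. As far as these compounds go, compound 4 sits at a limit of the assay and not at a number, so this step gives only a floor and its true size stays unknown. This is the first step at this position, and with bromo here the series gains no second real number, as one limit now holds most of the values: the limit of > 100000 nM in this assay, at which 3 of the 4 values shown sit.

From the compounds shown here alone, what an amine or a carboxylic acid on this aromatic carbon would give stays open. So does whether any group here can bring the number clearly below that of compound 2.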